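A few compounds are considered here, and "the series" means these few. Any claim that something is new, unique, unknown or untested is made for them only; others in the source may bear on it.

The measured compounds:

Compound 1 `CC1(C)CC(=O)Nc2ccc(Cl)cc21` gives 81.7% in a functional assay on MDA-MB-231 cells (Homo sapiens) for cytotoxicity, read by MTT assay, with a stated time of 72 h, tested at 5 uM, in the absence of a further agent; on this read-out higher numbers stand for a weaker effect at the one concentration tested and lower numbers for a stronger effect.
Compound 2 `CC1(C)CC(=S)Nc2ccc(Cl)cc21` gives 94.3% in this assay.
Compound 3 `CC1(C)CC(N)=Nc2ccc(Cl)cc21` gives 81% in this assay.

Compound 3 has the smallest of the three numbers, but its gap to compound 1 lies within the scatter of repeated measurements, so the two cannot be told apart; the gap to compound 2 lies beyond the scatter. Compound 4 `CCNC1=Nc2ccc(Cl)cc2C(C)(C)C1` differs from compound 3 in one place: ethyl in place of hydrogen on an amine nitrogen. Among the measured compounds shown here, no measured pair shows what this change does, so the step from compound 3 to compound 4 is expected to be no larger than the scatter, with no clear direction, a number 1 percentage points lower from compound 3 to compound 4 (within the scatter). Compound 4 is therefore estimated at 80% in this assay, within a range from 66% to 94%.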

Compound 4, a percentage reported as activity, at one concentration (the size of the read-out at that concentration, not a potency): 85.1%
Compound 4: the middle estimate sits 5.1 percentage points below what was measured, and the stated range covers the measured number.
By their numbers in this assay, from the lowest: compounds 3, 1, 4 and 2 (each within the scatter of the next, the first and the last beyond it).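

In this assay, among the compounds shown here, ethyl in place of hydrogen on an amine nitrogen gives a number 4.1 percentage points higher from compound 3 to compound 4 (within the scatter) and so provides the first measured step at this position. This single step shows that the ethyl group can stand on this nitrogen without a change that can be told from the scatter. Nothing available accounts for this result. 

On these data alone, whether a longer chain such as butyl or a larger group such as benzyl on this nitrogen would give a step beyond the scatter remains open. So does the effect of an acyl group at this position.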